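Notes on the sulfonyl aryl change, compound 1 to compound 3

The compounds below may be only part of what the source reports. "The series", "measured", "known", "first", "only" and "open" are said of these compounds alone.

Measured in a functional assay on MDA-MB-231 cells (Homo sapiens) for antiproliferative activity, read by MTT assay, with a stated time of 72 h; a higher number here means a weaker inhibitor, a lower number a stronger inhibitor:
- compound 1 `O=C(Nc1ccc(-c2noc(-c3cccc(NS(=O)(=O)c4ccccc4)c3)n2)c(Cl)c1)c1cccnc1`: compound 1 gives > 10000 nM, a limit of the assay.
- compound 2 `NS(=O)(=O)c1ccc(S(=O)(=O)Nc2cccc(-c3nc(-c4ccc(NC(=O)c5cccnc5)cc4Cl)no3)c2)cc1`: compound 2 gives > 10000 nM, also a limit.

Compound 1 stands at the assay limit, not at a number. For the measured compounds named here, the one measured step, a step that the two limits leave unreadable from compound 1 to compound 2, carries no readable size because of the limit of > 10000 nM in this assay, at which 2 of the 2 values shown sit. Compound 3 `CC(=O)Nc1ccc(S(=O)(=O)Nc2cccc(-c3nc(-c4ccc(NC(=O)c5cccnc5)cc4Cl)no3)c2)cc1Cl` differs from compound 1 by 4-acetamido-3-chlorophenyl in place of phenyl on a sulfonyl sulfur. Going by the values given here, no measured step bears on this change, so no direction beyond the scatter is expected. Compound 3 is estimated at 15000 nM, with a range of 3000 nM to 60000 nM, most likely again a limit. The step expected is a step that the limit leaves unreadable from compound 1 to compound 3.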

Compound 3, half-maximal inhibitory concentration: > 10000 nM
Compound 3: a limit, no number; the forecaster's own chance of this, stated with the estimate: 75%; the middle value is on the limit's open side.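

No step among compound 1, compound 2 and compound 3 can be read, as each stands at a limit and not at a number: the limit of > 10000 nM in this assay, at which 3 of the 3 values shown sit.

The compounds shown leave open whether either replacement of phenyl on the sulfonyl sulfur changes potency, and in which direction.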